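A few compounds are considered here, and "the series" means these few. Any claim that something is new, unique, unknown or untested is made for them only; others in the source may bear on it.

In an ADME assay for metabolic stability, read by HPLC, at pH 7 (on this read-out higher numbers stand for a longer-lived compound and lower numbers for a shorter-lived compound), compound 1 (`CCCCCCCCNC(=O)Oc1ccc(Cl)cc1C(=O)Nc1cccc(Cl)c1`) reads 64 h and compound 2 (`CCCCCCCCCNC(=O)Oc1ccc(Cl)cc1C(=O)Nc1cccc(Cl)c1`) reads 64 h and compound 3 (`CCCCCCCCCCNC(=O)Oc1ccc(Cl)cc1C(=O)Nc1cccc(Cl)c1`) reads 64 h on the same scale. Compound 2 therefore stands level with compounds 1 and 3. Compound 4 (`CCCCCCCCCNC(=O)Oc1ccc(Cl)cc1C(=O)Nc1ccc(Cl)cc1`) carries 4-chlorophenyl in place of 3-chlorophenyl on an amide-type nitrogen, and the difference from compound 2 is 4-chlorophenyl in place of 3-chlorophenyl on an amide-type nitrogen with the chain left as it is. For the measured compounds named here, all the measured steps lie in the saturated chain. The steps of no change at the digits printed from compound 1 to compound 2 (within the scatter) and no change at the digits printed from compound 2 to compound 3 (within the scatter) and no change at the digits printed from compound 1 to compound 3 (within the scatter) stay within the scatter. None of them covers a change in the chlorophenyl group, so they bear on this change only indirectly, and no measurement shows its direction. The estimated step is no change at the digits printed from compound 2 to compound 4 (within the scatter) and no move beyond the scatter is expected. Compound 4 is estimated at 64 h with 32 h and 120 h as the expected ends of the range.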

Compound 4, half-life: 64 h
For compound 4 middle estimate and measured number coincide at the digits printed, and the stated range covers the measured number.
By their numbers in this assay, from the lowest: compounds 1, 2, 3 and 4 (each within the scatter of the next).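

In this assay, 4-chlorophenyl in place of 3-chlorophenyl on the amide-type nitrogen gives no change at the digits printed from compound 2 to compound 4 (within the scatter) and is the only step shown outside the saturated chain. The half-life read-out therefore stays within the scatter for a change at this second site as well as for the chain steps, although this rests on one pair carrying the same chain. No measurement on hand accounts for this result.

On these data alone, it remains open whether the read-out would hold with a different group on this amide-type nitrogen, such as an unsubstituted phenyl, a pyridine or a phenyl bearing a carboxylic acid. As far as these compounds go, the same change on a much shorter chain, or an amine at the end of the chain, is also open.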